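Terminal methoxy on the amine chain of compound 2

The source may report more compounds than this note shows. Statements on the series, on what has been measured and on what is new or still open speak of the compounds shown alone.

Of the compounds shown here, two of the shared core carry numbers so far. Compound 1 `COCCN/C(=C1/N=C(C)N(CCOC)C1=O)c1cc2ccccc2[nH]1` gives 20 nM in an assay on isolated protein for inhibition of Calpain-1 catalytic subunit (Homo sapiens), read by fluorescence, with a stated time of 60 min; a lower number here means a stronger inhibitor, a higher number a weaker inhibitor. Among the measured compounds shown here, compound 2 `CCCCN/C(=C1/N=CN(CCOC)C1=O)c1cc2ccccc2[nH]1` gives 350 nM in this assay, the higher of the two numbers, and the only other compound, compound 1, sits lower, well beyond the scatter; compound 1 differs from compound 2 in more than one place, so nothing is drawn from that gap about any single change.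

Compound 3 `COCCCN/C(=C1/N=CN(CCOC)C1=O)c1cc2ccccc2[nH]1` is not yet measured. It differs from compound 2 by methoxy in place of methyl on a saturated chain carbon, three bonds along the chain from an amine nitrogen. For the measured compounds named here, no single-change step is known for this series, so the direction rests on the structures alone. A modest step toward a lower number in this assay is expected, a 2.3-fold lower number from compound 2 to compound 3 (0.37 log units; beyond the scatter), though a result within the scatter would not surprise. Compound 3 is estimated at 150 nM, between 40 nM and 600 nM.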

Compound 3, half-maximal inhibitory concentration: 1020 nM
Estimate against measurement, compound 3: 6.8-fold (0.83 log units) below; measured number outside the range, above it.
By their numbers in this assay, from the lowest: compound 1; then compound 2; then compound 3.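

In this assay, methoxy in place of methyl on a saturated chain carbon, three bonds along the chain from an amine nitrogen, gives a 2.9-fold higher number from compound 2 to compound 3 (0.46 log units; beyond the scatter). Among the compounds shown here, this is the only single-change step, and it shows that on this core the methoxy end of the 3-methoxypropyl chain does not lower the number relative to butyl. No measurement at hand explains the direction of this step.

Compound 1 differs from both compounds in more than one place, so its lower number cannot be assigned to its 2-methoxyethyl chain or to its extra methyl on the core. Also open, going by these compounds, is whether a hydroxyl, a terminal amine or a longer chain at this end would follow the same direction as methoxy.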